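Swapping the piperidine substituent in a potent antagonist series

This account rests on a few compounds, and the source may have more. Where it says the series, first, only, none or still open, it means among the compounds named here.

In a functional assay on CHO-K1 cells for antagonist activity at transient receptor potential cation channel subfamily V member 1 (Homo sapiens), read by FLIPR (a higher number here means a weaker inhibitor, a lower number a stronger inhibitor), compound 3 `CC(C(=O)NCc1ccc(C(F)(F)F)nc1N1CCC(C)(C)CC1)c1ccc(NS(C)(=O)=O)c(F)c1` gives 0.3 nM, the lowest of the three numbers recorded. Compound 1 `CC(C(=O)NCc1ccc(C(F)(F)F)nc1N(C)c1ccccc1)c1ccc(NS(C)(=O)=O)c(F)c1` gives 0.9 nM and compound 2 `CC(C(=O)NCc1ccc(C(F)(F)F)nc1N1CCCCC1C)c1ccc(NS(C)(=O)=O)c(F)c1` gives 2.9 nM; the step of a 3.0-fold lower number from compound 1 to compound 3 (0.48 log units; beyond the scatter) and the step of a 9.7-fold lower number from compound 2 to compound 3 (0.99 log units; beyond the scatter) both lie beyond the scatter, while a 3.2-fold higher number from compound 1 to compound 2 (0.51 log units; beyond the scatter) runs the other way. Compound 4 `CC(C(=O)NCc1ccc(C(F)(F)F)nc1N1CCC(C(F)(F)F)CC1)c1ccc(NS(C)(=O)=O)c(F)c1` differs from compound 3 by 4-(trifluoromethyl)piperidin-1-yl in place of 4,4-dimethylpiperidin-1-yl on an aromatic carbon. Within the data shown here, no measured step alters a substituent on a piperidin-1-yl ring in this way; the nearest is a 9.7-fold lower number from compound 2 to compound 3 (0.99 log units; beyond the scatter), which shows that the pattern of substitution on that ring can shift the number markedly. The step of a 2.0-fold higher number from compound 3 to compound 4 (0.30 log units; within the scatter) is therefore expected to be small, possibly within the scatter. For compound 4 the estimate is 0.6 nM, between 0.2 nM and 2 nM.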

Compound 4, inhibition constant: 0.6 nM
The estimate for compound 4 equals the measured number at the digits printed; measured number inside the range.
By their numbers in this assay, from the lowest: compounds 3, 4 and 1 (each within the scatter of the next, the first and the last beyond it); then compound 2.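

In this assay, 4-(trifluoromethyl)piperidin-1-yl can replace 4,4-dimethylpiperidin-1-yl without a resolved change (a 2.0-fold higher number from compound 3 to compound 4 (0.30 log units; within the scatter)). It also cannot be separated from the methyl(phenyl)amino group (a 1.5-fold lower number from compound 1 to compound 4 (0.18 log units; within the scatter)), yet it stands clear of 2-methylpiperidin-1-yl (a 4.8-fold lower number from compound 2 to compound 4 (0.68 log units; beyond the scatter)). This position next to the ring nitrogen therefore accepts two different 4-substituted piperidines, and among these compounds only compound 2 stands apart from compound 3 and compound 4. Going by these compounds, whether a carboxylic acid or an amine on that piperidine ring would fit equally well stays open. Nothing available here explains these numbers.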